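Swapping the Furanoyl Arm for a Dichlorophenyl Ring

This account rests on a few compounds, and the source may have more. Where it says the series, first, only, none or still open, it means among the compounds named here.

Of the compounds shown here, three that share one core have been tested in a functional assay on Jurkat cells for inhibition of nuclear factor NF-kappa-B complex (Homo sapiens); a higher number here means a weaker inhibitor, a lower number a stronger inhibitor. Compound 1 `CCOC(=O)c1cnc(-c2ccncc2)nc1NN1C(=O)C=C(C)C1=O` gives 6000 nM, compound 2 `CCOC(=O)c1cnc(-c2ccc(C)s2)nc1NN1C(=O)C=C(C)C1=O` gives 200 nM, and compound 3 `CCOC(=O)c1cnc(C(=O)c2ccco2)nc1NN1C(=O)C=C(C)C1=O` gives 700 nM. Compound 3 therefore stands second of the three: the step of a 3.5-fold higher number from compound 2 to compound 3 (0.54 log units; beyond the scatter) and the step of an 8.6-fold lower number from compound 1 to compound 3 (0.93 log units; beyond the scatter) place it between the other two, with both gaps beyond the scatter.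

Compound 4 `CCOC(=O)c1cnc(-c2cc(Cl)cc(Cl)c2)nc1NN1C(=O)C=C(C)C1=O` has not yet been measured. It differs from compound 3 in one place: 3,5-dichlorophenyl in place of (furan-2-yl)carbonyl on an aromatic carbon. The earlier steps shown here that bear on this position are a 30-fold lower number from compound 1 to compound 2 (1.48 log units; beyond the scatter) and an 8.6-fold lower number from compound 1 to compound 3 (0.93 log units; beyond the scatter); they show that this position accepts quite different groups and that the choice among them moves the number by a large margin. Compound 2 carries one five-membered aromatic ring at this position and compound 4 carries one six-membered aromatic ring of carbon only there, so the number for compound 4 is expected to sit nearer to compound 2 than to compound 1, because compound 2 gives 200 nM and compound 1 gives 6000 nM. This means an expected step of a 2.3-fold lower number from compound 3 to compound 4 (0.37 log units; beyond the scatter). With only three measured points the expectation is loose. Compound 4 is estimated at 300 nM, with a likely range from 80 nM to 1200 nM.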

Compound 4, half-maximal inhibitory concentration: 300 nM
For compound 4 middle estimate and measured number coincide at the digits printed; the measured number falls inside the stated range.
By their numbers in this assay, from the lowest: compounds 2 and 4 (each within the scatter of the next); then compound 3; then compound 1.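

In this assay the step of a 2.3-fold lower number from compound 3 to compound 4 (0.37 log units; beyond the scatter) shows that 3,5-dichlorophenyl, which has no hydrogen-bond acceptors, serves at least as well at this position as the (furan-2-yl)carbonyl arm with its two, so those acceptors are not required here. The step of a 1.5-fold higher number from compound 2 to compound 4 (0.18 log units; within the scatter) lies within the scatter, so a six-membered aromatic ring of carbon only and the five-membered 5-methylthiophen-2-yl ring cannot be told apart here, which means the position is not tied to one ring size among these compounds. The step of a 20-fold lower number from compound 1 to compound 4 (1.30 log units; beyond the scatter) gives a second large change away from pyridin-4-yl, and every other group shown also lies beyond the scatter from it, though nothing measured here explains these differences.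

The compounds shown leave open whether the two chlorine atoms matter at all, which an unsubstituted phenyl ring or a phenyl ring with one chlorine would test. They also leave open how a saturated ring such as morpholine or piperidine would behave at this position, and what a carboxylic acid or an amide in place of the ethoxycarbonyl group would do.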